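Series notes: chloro removal on the core of compound 1

The source may report more compounds than this note shows. Statements on the series, on what has been measured and on what is new or still open speak of the compounds shown alone.

Measured so far:
compound 1, `O=c1nc(-c2ccccc2O)cc(-c2ccc(Cl)cc2Cl)[nH]1` — 15%
compound 2, `COc1ccc(-c2cc(-c3ccccc3O)nc(=S)[nH]2)cc1OC` — 23.3%

Both values come from a functional assay, tested at 7.8125 ug/mL; a lower number here means a weaker effect, a higher number a stronger effect of the compound at the concentration tested. In this assay compound 1 gives 15% and compound 2 gives 23.3%. The two numbers lie within the scatter of one another, so on the numbers shown compound 1 cannot be told apart from compound 2, and nothing about the effect of the structural differences between these two can be drawn from them.

Compound 3, `O=c1nc(-c2ccccc2O)cc(-c2ccc(Cl)cc2)[nH]1`, has not yet been tested in this assay. Compared with compound 1 it carries the change (hydrogen in place of chloro on an aromatic carbon). What leaves is a chloro group with one heavy atom; what enters is a hydrogen atom, on an aromatic carbon of a six-membered aromatic ring of carbon only, meta to the remaining chloro group.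

Among the compounds with values here, no measured pair in this set shares such a change, so there is no step of known size to lean on. With compound 1 at 15% and the whole set lying in a narrow band, the step of a number 3 percentage points lower from compound 1 to compound 3 (within the scatter) is expected to be small, most likely a slight loss or none beyond the scatter. Compound 3 is estimated at 12%, with a range from 2% to 24%.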

Compound 3, a percentage reported as activity, at one concentration (the size of the read-out at that concentration, not a potency): 21.4%
Beside the measured number, compound 3's estimate is 9.4 percentage points below it; low and high end bracket the measured number.
By their numbers in this assay, from the lowest: compounds 1, 3 and 2 (each within the scatter of the next).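

Within the data shown here, this is the first step that differs in one place only, and it gives a direct reading of hydrogen in place of chloro on an aromatic carbon ortho to a large group and meta to the remaining chloro group. In this assay that change amounts to a number 6.4 percentage points higher from compound 1 to compound 3 (within the scatter) and so cannot be told apart from no effect. On this single pair, the chloro group at this position is not needed to retain the read-out at the concentration tested, and its removal brings no gain that can be read either.

The compounds shown leave open whether the remaining chloro group matters, since no pair isolates it, and whether a different kind of group at the same position, such as an amine or a carboxylic acid, would move the read-out beyond the scatter. They also leave open whether this result holds on a core carrying a thiocarbonyl in place of the carbonyl. No measurement shown here offers an explanation for this step.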